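A few compounds are considered here, and "the series" means these few. Any claim that something is new, unique, unknown or untested is made for them only; others in the source may bear on it.

Measured compounds in a functional assay on K562 cells (Homo sapiens) for inhibition; on this read-out lower numbers stand for stronger inhibition and higher numbers for weaker inhibition:
compound 1, `NC(=O)c1nn([C@@H]2O[C@H](CO)[C@@H](O)[C@H]2O)nc1C(N)=O`: 26 uM
compound 2, `NC(=O)c1cn(C2O[C@H](CO)[C@@H](O)[C@H]2O)nc1C(N)=O`: 160 uM

Compound 2 stands at the higher of the two numbers, its nearest neighbour being compound 1, whose number lies beyond the scatter below it. Compound 3, `NC(=O)c1nn(C2O[C@H](CO)[C@@H](O)[C@H]2O)c(N)c1C(N)=O`, is not yet measured. It differs from compound 2 by amino in place of hydrogen on an aromatic carbon, an amino in place of hydrogen on an aromatic carbon. Going by the values given here, no measured pair in this assay shows the effect of such a change, so the size of the step is open. A small move toward stronger inhibition is expected for compound 3, giving a 1.8-fold lower number from compound 2 to compound 3 (0.25 log units; within the scatter). The estimate for compound 3 in this assay is 90 uM, within 25 uM to 350 uM.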

Compound 3, concentration for 50% inhibition: 51 uM
Estimate against measurement, compound 3: 1.8-fold (0.25 log units) above; measured number inside the range.
By their numbers in this assay, from the lowest: compounds 1 and 3 (each within the scatter of the next); then compound 2.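

In this assay, going by these compounds alone, amino in place of hydrogen on the aromatic carbon next to the ring nitrogen gives a 3.1-fold lower number from compound 2 to compound 3 (0.50 log units; beyond the scatter) as the first one-place step. This carbon therefore accepts a substituent with no loss of inhibition, and the modest step lies beyond the scatter. Nothing available bears on the reason for this step. Going by these compounds, whether the change depends on amino itself stays open. A methyl group, a hydroxyl group or a longer chain such as aminoethyl on this carbon would test that.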